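The source may report more compounds than this note shows. Statements on the series, on what has been measured and on what is new or still open speak of the compounds shown alone.

Of the compounds shown here, three have so far been tested in a functional assay on U-937 cells (Homo sapiens) for cytotoxicity, read by MTT assay, with a stated time of 72 h; a higher number here means a weaker inhibitor, a lower number a stronger inhibitor. Compound 1 `Cc1c(C)c2c(c(C)c1O)CCC(C)(C(=O)NC1CC(C)(C)N([O])C(C)(C)C1)O2` gives 161000 nM. Compound 2 `Cc1c(C)c2c(c(C)c1OC(=O)CCC(=O)O)CCC(C)(C(=O)NC1CC(C)(C)N([O])C(C)(C)C1)O2` gives 123000 nM. Compound 3 `Cc1c(C)c2c(c(C)c1OC(=O)CCC(=O)NC1CC(C)(C)N([O])C1(C)C)CCC(C)(C(=O)NC1CC(C)(C)N([O])C1(C)C)O2` gives 75000 nM. Compound 3 shows the lowest of the three numbers; its gap to compound 1 lies beyond the scatter, but its gap to compound 2 lies within it, so no order between compound 3 and compound 2 can be read from these values.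

Compound 4 `Cc1c(C)c2c(c(C)c1OC(=O)CCC(=O)O)CCC(C)(C(=O)NC1CC(C)(C)N([O])C1(C)C)O2` is reached from compound 3 by a single change: one oxygen atom in place of a group of 11 heavy atoms (8 carbon, 2 nitrogen, 1 oxygen; one five-membered non-aromatic ring with 1 hetero atom), on a carbonyl carbon. Going by the values given here, the only measured step that changes one place, a 1.3-fold lower number from compound 1 to compound 2 (0.12 log units; within the scatter), concerns the oxygen on the aromatic ring of the shared core and shows that putting the (2-carboxyethyl)carbonyl group there hardly moved the number. Among the compounds with values here, no measured step sets a free acid against its amide on that arm; compound 2 and compound 3, which differ in more than one place, give values that lie within the scatter of each other. The expected step of a 1.5-fold higher number from compound 3 to compound 4 (0.17 log units; within the scatter) is therefore small, most likely none beyond the scatter, if anything toward a somewhat higher number. Compound 4 is estimated at 110000 nM, with a range from 55000 nM to 220000 nM.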

Compound 4, half-maximal inhibitory concentration: 163000 nM
Estimate against measurement, compound 4: 1.5-fold (0.17 log units) below; low and high end bracket the measured number.
By their numbers in this assay, from the lowest: compounds 3, 2, 1 and 4 (each within the scatter of the next, the first and the last beyond it).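

In this assay, going by these compounds alone, the change on the carbonyl carbon whose other neighbour is a saturated chain carbon, hydroxy in place of the group of 11 heavy atoms with its five-membered non-aromatic ring, gives a 2.2-fold higher number from compound 3 to compound 4 (0.34 log units; beyond the scatter) and so provides the first measured step at this place, a modest one that lies beyond the scatter. The change on the amide-type nitrogen, a group with a five-membered non-aromatic ring in place of one with a six-membered non-aromatic ring, gives a 1.3-fold higher number from compound 2 to compound 4 (0.12 log units; within the scatter) and shows no change that can be read from the scatter, so the ring size at that place makes no visible difference with the free acid on the arm. Nothing measured here accounts for either step.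

The compounds shown leave open whether the step on the carbonyl carbon depends on the ring of the departing group or on the amide link alone, which a methyl ester or a simple ethyl amide at that place would begin to separate. They also leave open whether the same ring exchange on the amide-type nitrogen would stay as small with the larger group on the carbonyl carbon.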